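The source may report more compounds than this note shows. Statements on the series, on what has been measured and on what is new or still open speak of the compounds shown alone.

Of the compounds shown here, three have been measured in a functional assay on the whole organism with Rattus norvegicus as the target; on this read-out higher numbers stand for an effect only at larger amounts of compound and lower numbers for an effect already at smaller amounts: compound 1 `CCOC(=O)C(=O)Nc1cc(N(C)C)ccc1C#N` gives 1.9 mg/kg, compound 2 `CCOC(=O)C(=O)Nc1cccc(NC)c1C#N` gives 0.2 mg/kg, and compound 3 `CCOC(=O)C(=O)Nc1cccc(N(CC)CC)c1C#N` gives 0.7 mg/kg.

Compound 3 stands second highest of the three numbers: compound 1 lies higher and compound 2 lower, both steps beyond the scatter. Compound 4 `CCOC(=O)C(=O)Nc1cccc(C(=O)OC)c1C#N` differs from compound 3 in one place: methoxycarbonyl in place of diethylamino on an aromatic carbon. Among the compounds with values here, the only measured step, a 3.5-fold higher number from compound 2 to compound 3 (0.54 log units; beyond the scatter), exchanges methylamino for diethylamino and so does not speak directly to an amine giving way to methoxycarbonyl. With no closer guide, the expectation for compound 4 is loosely held: a modest step toward a higher number, a 2.1-fold higher number from compound 3 to compound 4 (0.33 log units; beyond the scatter), is expected, within a wide range. Compound 4 is therefore estimated at 1.5 mg/kg, between 0.4 mg/kg and 6 mg/kg.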

Compound 4, dose for half-maximal effect: 1.2 mg/kg
Beside the measured number, compound 4's estimate is 1.3-fold (0.10 log units) above it; the range from low to high includes it.
By their numbers in this assay, from the lowest: compound 2; then compounds 3, 4 and 1 (each within the scatter of the next, the first and the last beyond it).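

In this assay, methoxycarbonyl in place of diethylamino gives a 1.7-fold higher number from compound 3 to compound 4 (0.23 log units; within the scatter), so at this place ortho to the cyano group, an amine is not needed to hold the level of compound 3. Methylamino stays apart from the ester, with a 6.0-fold higher number from compound 2 to compound 4 (0.78 log units; beyond the scatter), which shows that the choice of group here can still move the number beyond the scatter. Nothing available explains either step. Still open, going by these compounds, is whether an unsubstituted amine would fall nearer compound 2 or compound 4. A carboxylic acid or a longer ester chain at this place is also untested among the compounds shown.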